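This account rests on a few compounds, and the source may have more. Where it says the series, first, only, none or still open, it means among the compounds named here.

Of the compounds shown here, three that share one core have been measured, and a fourth is now to be placed against them. Compound 1 `C=C1C(=O)O[C@@H](c2ccccc2)[C@H]1c1ccccc1` and compound 2 `C=C1C(=O)O[C@H](c2ccccc2)[C@H]1c1ccccc1` were tested in a functional assay on MIA PaCa-2 cells (Homo sapiens) for cytotoxicity, read by MTT assay, with a stated time of 72 h, tested at 1 uM (on this read-out higher numbers stand for a weaker effect at the one concentration tested and lower numbers for a stronger effect), where compound 1 gives 32% and compound 2 gives 30%. The pair shows a number 2 percentage points lower from compound 1 to compound 2 (within the scatter), and the only thing separating them is the fact that compounds 1 and 2 differ only in the configuration as drawn. Compound 3 `C=C1C(=O)O[C@H](c2ccc(OC)cc2)[C@H]1c1ccccc1` carries a methoxy on one phenyl and in this assay gives 54%, the highest of the three numbers, after a number 24 percentage points higher from compound 2 to compound 3 (beyond the scatter).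

Compound 4 `C=C1C(=O)O[C@H](c2ccc(C(F)(F)F)cc2)[C@H]1c1ccccc1` is the untested one. It differs from compound 3 by trifluoromethyl in place of methoxy on an aromatic carbon. Within the data shown here, no measured step swaps one substituent for another at that ring carbon; the closest guide is the methoxy step, where adding a group there raised the number. Trifluoromethyl is a different group, so the expected step of a number 9 percentage points lower from compound 3 to compound 4 (within the scatter) is small and may not reach beyond the scatter. Compound 4 is therefore estimated at 45% in this assay, with a range from 25% to 65%.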

Compound 4, a percentage reported as activity, at one concentration (the size of the read-out at that concentration, not a potency): 142%
The estimate for compound 4 lay 97 percentage points below the measured number; measured number outside the range, above it.
By their numbers in this assay, from the lowest: compounds 2 and 1 (each within the scatter of the next); then compound 3; then compound 4.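

In this assay, among these compounds, what stands on this aromatic carbon turns out to matter far more than the earlier compounds could show. Replacing hydrogen with trifluoromethyl gives a number 112 percentage points higher from compound 2 to compound 4 (beyond the scatter), and that step is much larger than the one seen with methoxy, a number 24 percentage points higher from compound 2 to compound 3 (beyond the scatter), so the two groups move the number in the same direction but by very different amounts, and exchanging one for the other still gives a number 88 percentage points higher from compound 3 to compound 4 (beyond the scatter). On this read-out a higher number means a weaker effect, so this one change at a single place removes most of the effect seen for compound 2, and nothing known about these compounds explains why the step is so large.

On these data alone, with only hydrogen, methoxy and trifluoromethyl at this place, it remains open where an amine, a carboxylic acid or a single chlorine atom would fall relative to compound 2 and compound 4. As far as these compounds go, compound 3 and compound 4 are both drawn with the configuration of compound 2, so it also remains open whether trifluoromethyl would give a step of similar size on the configuration of compound 1.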